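Volume of distribution: ring amine to acyclic amine

The source may hold more compounds than are shown below. What is called first, only, known or untested is meant among the compounds shown, and "the series" means these compounds.

Three compounds of the series have numbers in an in vivo ADME assay on the whole organism for pharmacokinetics, with Canis familiaris (Canis lupus familiaris) as the target; a lower number here means that more of the compound stays in the plasma, a higher number that more of the compound sits outside the plasma. Compound 1 `Nc1noc2ccc(-n3nc(C(F)(F)F)c4c3C(=O)N(c3ccc(-c5ccccc5CN5CCCC5)cc3)CC4)cc12` gives 5 L/kg. Compound 3 `CNCc1ccccc1-c1ccc(N2CCc3c(C(F)(F)F)nn(-c4ccc5onc(N)c5c4)c3C2=O)cc1` gives 9.7 L/kg. Compound 2 `Nc1noc2ccc(-n3nc(C(F)(F)F)c4c3C(=O)N(c3ccc(-c5ccccc5CN5CC[C@@H](O)C5)cc3F)CC4)cc12` gives 2.8 L/kg, the lowest of the three; against compound 1 the gap is within the scatter, against compound 3 it is beyond it.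

Compound 4 `CN(C)Cc1ccccc1-c1ccc(N2CCc3c(C(F)(F)F)nn(-c4ccc5onc(N)c5c4)c3C2=O)c(F)c1` is not yet measured. It differs from compound 2 in one place: dimethylamino in place of 3-hydroxypyrrolidin-1-yl on a saturated chain carbon bound to an aromatic carbon

Within the data shown here, one measured step bears on this change, the replacement of the cyclic amine by an acyclic one: a 1.9-fold higher number from compound 1 to compound 3 (0.29 log units; within the scatter). That step stayed within the scatter, and the same kind of swap from compound 2 to compound 4 is therefore expected to move the number only modestly, if at all, toward a higher value. The step from compound 2 to compound 4 is estimated at a 1.6-fold higher number from compound 2 to compound 4 (0.21 log units; within the scatter). Compound 4 is expected to give about 4.5 L/kg, likely between 2.5 L/kg and 8 L/kg.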

Compound 4, volume of distribution at steady state: 8.8 L/kg
Compound 4: middle estimate off by 2.0-fold (0.29 log units), on the low side; the whole stated range lies below it.
By their numbers in this assay, from the lowest: compounds 2, 1, 4 and 3 (each within the scatter of the next, the first and the last beyond it).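

In this assay, among these compounds, the change at the saturated chain carbon bound to an aromatic carbon gives a 3.1-fold higher number from compound 2 to compound 4 (0.50 log units; beyond the scatter), a step beyond the scatter, whereas the one earlier exchange of a ring amine for an acyclic amine gave a 1.9-fold higher number from compound 1 to compound 3 (0.29 log units; within the scatter) and stayed within it. An exchange of this kind at this place can therefore move the number beyond the scatter, at least when 3-hydroxypyrrolidin-1-yl leaves and dimethylamino enters, a change that removes the ring, the defined stereocentre and the hydrogen-bond donor of the group together. No measurement shown accounts for the size of this step.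

The compounds shown leave open how much of the step belongs to the hydroxyl and how much to the ring, as no pair differs by the hydroxyl alone. Also open, on these data alone, is where a morpholin-4-yl or a piperidin-1-yl group at this place would fall.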